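A few compounds are considered here, and "the series" means these few. Any claim that something is new, unique, unknown or untested is made for them only; others in the source may bear on it.

Measured so far in an assay on liver for inhibition of sterol O-acyltransferase 1 (Rattus norvegicus), using microsomes; on this read-out lower numbers stand for stronger inhibition and higher numbers for weaker inhibition:

Compound 1, `CC(C)c1cccc(C(C)C)c1OS(=O)(=O)NC(=O)Oc1ccc(F)cc1`, reaches only the assay limit of > 50000 nM.
Compound 2, `CC(C)c1cccc(C(C)C)c1OS(=O)(=O)NC(=O)Oc1ccc(F)cc1F`, likewise stops at the assay limit of > 50000 nM.
Compound 3, `CC(C)c1cc(C(C)(C)C)cc(C(C)C)c1OC(=O)NS(=O)(=O)Oc1c(C(C)C)cccc1C(C)C`, gives 8800 nM.

Compound 3 is thus the only one of the three with a real number in this assay; the other two sit at a limit, and so nothing can be said about how they compare with it. Among the compounds with values here, the single step between measured compounds, a step that the two limits leave unreadable from compound 1 to compound 2, cannot be sized because of the limit of > 50000 nM in this assay, at which 2 of the 3 values shown sit.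

Compound 4, `CC(C)c1cc(Cl)cc(C(C)C)c1OC(=O)NS(=O)(=O)Oc1c(C(C)C)cccc1C(C)C`, has not yet been measured in this assay. It differs from compound 3 in one place: chloro in place of tert-butyl on an aromatic carbon, in words chloro in place of tert-butyl on an aromatic carbon. Within the data shown here, no measured step involves a change of this kind, and the one step available is unreadable, so nothing in the data points to a shift in either direction. The step that the estimate below means, a 1.1-fold higher number from compound 3 to compound 4 (0.06 log units; within the scatter), is therefore expected to stay within the usual scatter. Compound 4 is estimated at 10000 nM, with a range from 3000 nM to 40000 nM.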

Compound 4, half-maximal inhibitory concentration: 42000 nM
Estimate against measurement, compound 4: 4.2-fold (0.62 log units) below; measured number above the stated range.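

In this assay, within the data shown here, swapping tert-butyl for chloro on this aromatic carbon, para to a large group, gives a 4.8-fold higher number from compound 3 to compound 4 (0.68 log units; beyond the scatter) and is the first step here whose size can be read. It shows that inhibition in this series responds to what sits at this position, and that of these two groups, tert-butyl, with 4 heavy atoms, gives the stronger inhibition and chloro, with 1 heavy atom, the weaker. Nothing measured here says why the number moves.

Other groups at this position, such as a plain hydrogen, a methyl, a trifluoromethyl or an amine, would show whether the number simply follows the count of heavy atoms or depends on something else. Going by these compounds, whether this swap acts the same way on a different core also remains open.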